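Cinnamamide series: methyl position versus ring halogen

A few compounds are considered here, and "the series" means these few. Any claim that something is new, unique, unknown or untested is made for them only; others in the source may bear on it.

Three members have been measured in a functional assay on K562 cells (Homo sapiens) for antiproliferative activity, read by trypan blue exclusion, with a stated time of 48 h, tested at 10 uM; a higher number here means more inhibition of growth at the concentration tested, a lower number less inhibition of growth. Compound 1 `Cc1cccc(/C=C/C(=O)Nc2ccc(Cl)cc2C(N)=O)c1` gives 37.8% in this assay. Compound 2 `Cc1ccc(/C=C/C(=O)Nc2ccc(Cl)cc2C(N)=O)cc1` gives 64%. Compound 3 `Cc1cccc(/C=C/C(=O)Nc2ccc(Br)cc2C(N)=O)c1` gives 43.8%.

The change from compound 1 to compound 2 is 4-methylphenyl in place of 3-methylphenyl on a double-bonded chain carbon bound to a double-bonded chain carbon, and the step it made is a number 26.2 percentage points higher from compound 1 to compound 2 (beyond the scatter). The change from compound 1 to compound 3 is bromo in place of chloro on an aromatic carbon, with a step of a number 6 percentage points higher from compound 1 to compound 3 (within the scatter). Compound 2 and compound 3 are not paired by a single change; compound 2 sits above compound 3 by more than the scatter.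

Compound 4 `Cc1ccc(/C=C/C(=O)Nc2ccc(Br)cc2C(N)=O)cc1` awaits measurement. It differs from compound 3 by 4-methylphenyl in place of 3-methylphenyl on a double-bonded chain carbon bound to a double-bonded chain carbon, which is the same change as that from compound 1 to compound 2; the two cores on which it is made differ by bromo in place of chloro on an aromatic carbon. Because on the core of compound 1 this change produced a number 26.2 percentage points higher from compound 1 to compound 2 (beyond the scatter), a step of similar size is expected on the core of compound 3, with some allowance for a single-pair precedent and the scatter of this read-out. The expected step from compound 3 to compound 4 is a number 20.2 percentage points higher from compound 3 to compound 4 (beyond the scatter). Compound 4 is accordingly estimated at 64%, with a plausible range from 48% to 78%.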

Compound 4, percent growth inhibition at one concentration: 45.9%
Beside the measured number, compound 4's estimate is 18.1 percentage points above it; the measured number lies below the stated range.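

The change to 4-methylphenyl in place of 3-methylphenyl now gives a number 2.1 percentage points higher from compound 3 to compound 4 (within the scatter), so in this assay the size of this step does not carry from one core to the other: the same change on two cores in this assay, a number 26.2 percentage points higher (beyond the scatter) from compound 1 to compound 2 and a number 2.1 percentage points higher (within the scatter) from compound 3 to compound 4, 24.1 percentage points apart, beyond the scatter of two such steps

Read along the other edge of the same four compounds, bromo in place of chloro gives a number 18.1 percentage points lower from compound 2 to compound 4 (beyond the scatter), so the effects of the halogen and of the methyl position do not simply add in this set: the same change on two cores in this assay, a number 6 percentage points higher (within the scatter) from compound 1 to compound 3 and a number 18.1 percentage points lower (beyond the scatter) from compound 2 to compound 4, 24.1 percentage points apart, beyond the scatter of two such steps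

These four compounds form only one such square, with a single reading at one concentration for each compound, so they do not show which step would be the more typical on further cores, and they give no reason for the gap.

As far as these compounds go, it remains open whether the same dependence appears with fluoro or iodo in place of the halogen, or with ethyl or methoxy in place of the methyl group on the phenyl ring. Also open, from the compounds shown here alone, is whether a full concentration series would rank these compounds as the single-concentration read-out does.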